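Swapping Dipropylamino for a Bulkier Secondary Amine

The compounds below may be only part of what the source reports. "The series", "measured", "known", "first", "only" and "open" are said of these compounds alone.

Compound 1 `CCCNCCCOc1ccc2cc(NC(=O)c3ccc(O)c(CC=C(C)C)c3)c(=O)oc2c1C` gives 980 nM in a functional assay on MCF7 cells (Homo sapiens) for antiproliferative activity; on this read-out lower numbers stand for stronger inhibition and higher numbers for weaker inhibition. Compound 2 `CCCN(CCC)CCCOc1ccc2cc(NC(=O)c3ccc(O)c(CC=C(C)C)c3)c(=O)oc2c1C` gives only a limit in this assay, > 50000 nM. Compound 3 `CC(C)=CCc1cc(C(=O)Nc2cc3ccc(OCCCN[C@H](C)c4ccccc4)c(C)c3oc2=O)ccc1O` gives 1450 nM.

Within the data shown here, compound 2 is thus the one compound whose result is a limit rather than a number (the limit of > 50000 nM in this assay, at which 1 of the 3 values shown sits). Compound 4 `CC(C)=CCc1cc(C(=O)Nc2cc3ccc(OCCCNC(C)(C)c4ccccc4)c(C)c3oc2=O)ccc1O` differs from it by (1-methyl-1-phenylethyl)amino in place of dipropylamino on a saturated chain carbon, three bonds along the chain from an oxygen on an aromatic ring. Among the measured compounds shown here, two measured steps bear on this change: an at least 51-fold higher number from compound 1 to compound 2 (1.70 log units; beyond the scatter) and an at least 34-fold lower number from compound 2 to compound 3 (1.53 log units; beyond the scatter), both large and beyond the scatter, and in both the amine nitrogen carrying a hydrogen rather than two propyl groups goes with the far lower number. Compound 4 again carries a hydrogen on that nitrogen, so a large drop is expected, an at least 25-fold lower number from compound 2 to compound 4 (1.39 log units; beyond the scatter). Compound 4 is therefore estimated at 2000 nM, within 600 nM to 7000 nM.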

Compound 4, half-maximal inhibitory concentration: 1070 nM
Estimate against measurement, compound 4: 1.9-fold (0.27 log units) above; the measured number falls inside the stated range.
By their numbers in this assay, from the lowest: compounds 1, 4 and 3 (each within the scatter of the next). At a limit, above all of these: compound 2.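

The result for compound 2 is a limit, not a number: the limit of > 50000 nM in this assay, at which 1 of the 4 values shown sits.

Replacing dipropylamino with (1-methyl-1-phenylethyl)amino gives an at least 46-fold lower number from compound 2 to compound 4 (1.66 log units; beyond the scatter). Among the amines that keep a hydrogen on the nitrogen, the steps are a 1.4-fold lower number from compound 3 to compound 4 (0.13 log units; within the scatter) and a 1.1-fold higher number from compound 1 to compound 4 (0.04 log units; within the scatter), so propyl, 1-phenylethyl and 1-methyl-1-phenylethyl read alike on this nitrogen in the compounds shown.

On these data alone, compound 2 alone lacks a hydrogen on that nitrogen, and whether a dimethylamino or piperidine group there would behave like dipropylamino stays open.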